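The source may report more compounds than this note shows. Statements on the series, on what has been measured and on what is new or still open speak of the compounds shown alone.

Working notes on the series in a functional assay on A549 cells (Homo sapiens) for antiproliferative activity, read by MTT assay, with a stated time of 24 h; a lower number here means a stronger inhibitor, a higher number a weaker inhibitor. Compound 1 `Cc1ccc(-c2nn(-c3ccccc3)cc2-c2nc3ccccc3n2S(=O)(=O)c2ccc(C)cc2)cc1` gives 460 nM and compound 2 `Cc1ccc(-c2nn(-c3ccccc3)cc2-c2nc3ccccc3n2S(=O)(=O)c2ccc(Cl)cc2)cc1` gives 3550 nM, so compound 2 holds the higher, weaker of the two numbers. The next analogue, compound 3 `Cc1ccc(-c2nn(-c3ccccc3)cc2-c2nc3ccccc3n2S(=O)(=O)c2ccc(C(F)(F)F)cc2)cc1`, has not yet been measured. The change leading to it from compound 2 is trifluoromethyl in place of chloro on an aromatic carbon, para to a large group.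

Within the data shown here, only one measured step bears on this: a 7.7-fold higher number from compound 1 to compound 2 (0.89 log units; beyond the scatter), a modest change with chloro in place of methyl on the same aromatic carbon. It shows that a swap at this place can move the number beyond the scatter, but it does not include trifluoromethyl, and two compounds give no trend. A change smaller than that step is therefore expected, probably within the scatter, with only a weak lean towards a lower number. The expected step is a 1.3-fold lower number from compound 2 to compound 3 (0.10 log units; within the scatter). For compound 3 the estimated value is 2800 nM, with an expected range of 700 nM to 9000 nM.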

Compound 3, half-maximal inhibitory concentration: 1460 nM
Compound 3: middle estimate off by 1.9-fold (0.28 log units), on the high side; low and high end bracket the measured number.
By their numbers in this assay, from the lowest: compound 1; then compound 3; then compound 2.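

In this assay, trifluoromethyl in place of chloro gives a 2.4-fold lower number from compound 2 to compound 3 (0.39 log units; beyond the scatter), so the step seen earlier at this aromatic carbon is not a one-way loss on moving away from methyl: the position separates chloro from trifluoromethyl as well. Methyl still holds the lowest number of the three, with a 3.2-fold higher number from compound 1 to compound 3 (0.50 log units; beyond the scatter) for trifluoromethyl in its place, and the order methyl, trifluoromethyl, chloro does not follow heavy-atom count across chloro and trifluoromethyl, since the group with 4 heavy atoms gives the lower number than the group with 1. Nothing at hand accounts for this order.

Going by these compounds, three groups at one place give a ranking rather than a trend, and it remains open where a methoxy group, a nitrile, an amine, a carboxylic acid or a longer alkyl chain at this place would fall relative to methyl. On these data alone, it is also open whether the same order would hold if the shared core were changed elsewhere.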